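The source may report more compounds than this note shows. Statements on the series, on what has been measured and on what is new or still open speak of the compounds shown alone.

For the measured compounds named here, compound 1, whose structure is `COc1ccc(OCCCON2C(N)=NC(N)=NC23CCOCC3)cc1`, is the only compound here with a number to stand on. In an assay on isolated protein for inhibition of Dihydrofolate reductase (Homo sapiens), read by spectrophotometry, using NADPH, with stated times of 5 s and 6 min (on this read-out higher numbers stand for weaker inhibition and lower numbers for stronger inhibition), compound 1 gives 11.1 nM. A second compound, compound 2, with structure `NC1=NC2(CCSCC2)N(OCCCOc2cccc(Cl)c2)C(N)=N1`, belongs to the same series, but for compound 2 the entry in this assay reads "not determined" (no result reported), so it adds no number and no comparison can be drawn from it. Compound 1 therefore stands alone, with nothing to rank it against.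

The next compound, compound 3, has structure `NC1=NC2(CCOCC2)N(OCCCOc2ccc(Br)cc2)C(N)=N1`. It differs from compound 1 in one place only: bromo in place of methoxy on an aromatic carbon. Compound 1 carries a methoxy on an aromatic carbon of a six-membered aromatic ring of carbon only, para to a large group, and compound 3 carries a bromo there instead.

Going by the values given here, no measured pair shows what this exchange does. With only compound 1 as an anchor, the step from compound 1 to compound 3 is expected to be small, in a 1.2-fold lower number from compound 1 to compound 3 (0.09 log units; within the scatter), and not clearly beyond the usual scatter of this assay. Compound 3 is therefore expected to give 9 nM in this assay, with a likely range from 3 nM to 27 nM.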

Compound 3, half-maximal inhibitory concentration: 32.5 nM
Beside the measured number, compound 3's estimate is 3.6-fold (0.56 log units) below it; the whole stated range lies below it.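

Exchanging methoxy for bromo at this place is not a neutral swap in this assay: the change gives a 2.9-fold higher number from compound 1 to compound 3 (0.47 log units; beyond the scatter). A higher number means weaker inhibition here. The methoxy compound is the better of this pair. The step is modest, but it shows that this aromatic carbon, para to a large group, responds to what it carries, which a single value for compound 1 and an entry without a result for compound 2 could not show. No measurement offered here explains the difference, so it stands as an observation without a known cause.

This single pair leaves open how other groups at this place, such as an amine, a hydroxyl or an ethoxy, would compare with methoxy and bromo, and so whether methoxy is unusually favourable or bromo unusually poor. It also cannot show whether the same exchange would give a step of similar size on a different core, such as that of compound 2, which has no number to compare.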